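The compounds below may be only part of what the source reports. "The series", "measured", "known", "first", "only" and "open" are said of these compounds alone.

Measured compounds:
- compound 1 `O=C(NCc1cccc(Cn2cnc3ccccc32)c1)c1cc2ccccc2[nH]1`: 72 nM
- compound 2 `O=C(NCc1cccc(Cn2cnc3ccccc32)c1)c1cc2cc(O)ccc2[nH]1`: 781 nM

Going by the values given here, compound 2 stands highest of the two numbers in an assay for inhibition of Indoleamine 2,3-dioxygenase 1 (Homo sapiens), read by HPLC, with a stated time of 48 h; on this read-out lower numbers stand for stronger inhibition and higher numbers for weaker inhibition; its nearest neighbour is compound 1, and the step of an 11-fold higher number from compound 1 to compound 2 (1.04 log units; beyond the scatter) is the only measured step in this set. It shows that changing the ring attached to the carbonyl carbon moves this assay strongly.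

Compound 3 `O=C(NCc1cccc(Cn2cnc3ccccc32)c1)c1ccc(Br)cc1` has not yet been measured. It differs from compound 2 as follows: 4-bromophenyl in place of 5-hydroxy-1H-indol-2-yl on a carbonyl carbon. Among the compounds with values here, the one measured step, an 11-fold higher number from compound 1 to compound 2 (1.04 log units; beyond the scatter), touches the same ring but not this exchange, so it only tells that this part of the molecule is sensitive. Nothing measured here shows what removing the whole 5-hydroxy-1H-indol-2-yl group does. Given that compound 2 already gives 781 nM and that no measured compound carries a 4-bromophenyl there, compound 3 is expected to land near compound 2 with wide uncertainty, an expected step of a 1.3-fold higher number from compound 2 to compound 3 (0.11 log units; within the scatter). The estimate for compound 3 in this assay is 1000 nM, with a range from 200 nM to 5000 nM.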

Compound 3, half-maximal inhibitory concentration: 134 nM
Estimate against measurement, compound 3: 7.5-fold (0.87 log units) above; the measured number lies below the stated range.
By their numbers in this assay, from the lowest: compounds 1 and 3 (each within the scatter of the next); then compound 2.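

In this assay, 4-bromophenyl in place of 5-hydroxy-1H-indol-2-yl on the carbonyl carbon gives a 5.8-fold lower number from compound 2 to compound 3 (0.77 log units; beyond the scatter), while the same group in place of 1H-indol-2-yl gives a 1.9-fold higher number from compound 1 to compound 3 (0.27 log units; within the scatter). This position therefore does not need the two-ring 1H-indol-2-yl group to reach the level of compound 1: a single six-membered aromatic ring of carbon only, carrying bromine, does so with fewer heavy atoms, and among the three compounds only the hydroxy-bearing compound 2 stands apart. Nothing available here explains why these exchanges have these outcomes.

The compounds shown leave open what the bromine itself contributes, which a plain phenyl, a 4-chlorophenyl or a 4-methoxyphenyl group on the carbonyl carbon would help to separate. Also open, going by these compounds, is whether a hydroxy group on the phenyl ring would raise the number as it does on the indole, and how an amine or a carboxylic acid would fare on that ring.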